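Swapping Ethoxy for Fluoro: An Expected Lipophilicity Shift

The source may hold more compounds than are shown below. What is called first, only, known or untested is meant among the compounds shown, and "the series" means these compounds.

Values measured in a physicochemical assay for lipophilicity; on this read-out lower numbers stand for lower lipophilicity and higher numbers for higher lipophilicity:
Compound 1 `Ic1ccccc1-c1ncco1`: 2.3
Compound 2 `CCOc1ccccc1C1=NC(c2ccccc2)CO1`: 4.22
Compound 3 `COc1cccc(C2=NC(c3ccccc3)CO2)c1`: 3.77

Compound 2, at 4.22, stands highest of these three in this assay. Its nearest neighbour is compound 3 at 3.77, a gap beyond the scatter. Furthest away is compound 1 at 2.3, again well beyond the scatter.

The next compound to be measured is compound 4 `Fc1ccccc1C1=NC(c2ccccc2)CO1`. It differs from compound 2 in one place, with fluoro in place of ethoxy on an aromatic carbon, ortho to a large group: fluoro in place of ethoxy on an aromatic carbon. For the measured compounds named here, no measured pair in this set differs in only one place, so the size of this step has no direct precedent, and any forecast remains tentative. Compound 2 shares its core with compound 3, which reads 3.77, and this shows that a compound with this core can sit clearly lower. A moderate fall beyond the scatter is therefore expected, and the estimated change is a number 0.47 log units lower from compound 2 to compound 4 (beyond the scatter). For compound 4 the estimated value in this assay is 3.75, with an expected range from 3.35 to 4.15.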

Compound 4, partition coefficient: 3.51
Estimate against measurement, compound 4: 0.24 log units above; low and high end bracket the measured number.
By their numbers in this assay, from the lowest: compound 1; then compounds 4 and 3 (each within the scatter of the next); then compound 2.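

In this assay, for the compounds shown here, the pair of compound 2 and compound 4 is the first in this set to differ in one place only, so the position now has a measured step: fluoro in place of ethoxy on an aromatic carbon, ortho to a large group, gives a number 0.71 log units lower from compound 2 to compound 4 (beyond the scatter). The step ties a shift beyond the scatter to a single exchange, in which ethoxy, with 3 heavy atoms and 1 hydrogen-bond acceptor, gives way to fluoro, with 1 heavy atom and 0 hydrogen-bond acceptors, while the rest of the structure stays the same. No measurement shown here bears on why the number moves.

With only one step at this position, the compounds shown leave open how other groups would read in the same place, such as methoxy, chloro or an amine, and so whether the read-out tracks the heavy-atom count at all. They also leave open whether the same exchange would give a step of similar size at another place on the ring or on a different core.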